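Swapping a hydroxyphenyl for a methylpyrazolyl in compound 4

This account rests on a few compounds, and the source may have more. Where it says the series, first, only, none or still open, it means among the compounds named here.

Measured so far in an assay on cells for inhibition of S-adenosylmethionine decarboxylase proenzyme (Homo sapiens), read by mass spectrometry, at pH 7.2; on this read-out higher numbers stand for weaker inhibition and lower numbers for stronger inhibition:
Compound 1, `Cc1cc(Nc2cccc(Cl)c2)nc(N)n1`, gives only a limit of this assay, > 180000 nM.
Compound 2, `Cc1ccc(-c2cc(Cl)cc(Nc3cc(C)nc(N)n3)c2)cc1`, gives only a limit of this assay, > 63000 nM.
Compound 3, `Cc1cc(Nc2cc(Cl)cc(-c3ccc(O)cc3)c2)nc(N)n1`, gives only a limit of this assay, > 180000 nM.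

Compound 3 therefore stands at the upper edge of what this assay can report, the same edge as compound 1 (the limit of > 180000 nM in this assay, at which 2 of the 3 values shown sit). Compound 2 stops at a different edge (the limit of > 63000 nM in this assay, at which 1 of the 3 values shown sits). Every value is a limit. The steps among them cannot be sized: a step that the two limits leave unreadable from compound 1 to compound 2, a step that the two limits leave unreadable from compound 1 to compound 3 and a step that the two limits leave unreadable from compound 2 to compound 3 all stay unreadable.

Compound 4, `Cc1cc(Nc2cc(Cl)cc(-c3cnn(C)c3)c2)nc(N)n1`, differs from compound 3 in one place: 1-methyl-1H-pyrazol-4-yl in place of 4-hydroxyphenyl on an aromatic carbon. Among the measured compounds shown here, the steps that bear on this change are exactly the unreadable ones, so no direction and no size beyond the scatter can be drawn from them. Compound 4 is therefore expected to remain a limit as well, with an estimated step that the limit leaves unreadable from compound 3 to compound 4. The estimate for compound 4 in this assay is 200000 nM, ranging from 50000 nM to 1000000 nM.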

Compound 4, half-maximal inhibitory concentration: > 180000 nM
Compound 4: no number, only a limit; the forecaster's own chance of this, stated with the estimate: 85%; the middle value does not contradict the limit.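

In this assay compound 4 gives only a limit, > 180000 nM. Among the compounds shown here, compound 1, compound 2 and compound 3 also give only limits, so no step from any of them to compound 4 can be read. On these data alone, what stays open is whether any group at this place on the shared core would give an actual number in this assay.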